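A few compounds are considered here, and "the series" means these few. Any claim that something is new, unique, unknown or untested is made for them only; others in the source may bear on it.

Working notes on the series. Among the measured compounds shown here, in a functional assay on DU-145 cells (Homo sapiens) for inhibition, read by trypan blue exclusion, with a stated time of 96 h (on this read-out higher numbers stand for weaker inhibition of growth and lower numbers for stronger inhibition of growth), compound 2 (`COc1ccc(/C=C(/Sc2ccc(C)cc2)C(=O)c2ccc(Cl)cc2)cc1O`) gives 1000 nM, the lower of the two numbers so far. Compound 1 (`O=C(/C(=C\c1ccc(Cl)cc1Cl)S(=O)(=O)c1ccc(Br)cc1)c1ccc(Cl)cc1`) gives 50000 nM, a gap from compound 2 that lies beyond the scatter. Compound 3 (`COc1ccc(/C=C(\C(=O)c2ccc(Cl)cc2)S(=O)(=O)c2ccc(Br)cc2)cc1O`) is next for this assay. Its change from compound 2 is (4-bromophenyl)sulfonyl in place of (4-methylphenyl)sulfanyl on a double-bonded chain carbon bound to a carbonyl carbon and a double-bonded chain carbon. For the measured compounds named here, compound 1 also carries (4-bromophenyl)sulfonyl, but it differs from compound 3 elsewhere as well, and no measured pair isolates this swap. The expectation therefore rests on thin ground: compound 1, at 50000 nM, points towards weaker inhibition of growth, with compound 2, at 1000 nM, as the starting point. A moderate rise, just beyond the scatter, is expected, estimated as a 3.0-fold higher number from compound 2 to compound 3 (0.48 log units; beyond the scatter). The estimate for compound 3 is 3000 nM, with an expected range of 300 nM to 20000 nM.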

Compound 3, concentration for 50% growth inhibition: 10000 nM
Compound 3: the middle estimate sits 3.3-fold (0.52 log units) below what was measured; measured number inside the range.
By their numbers in this assay, from the lowest: compound 2; then compound 3; then compound 1.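

In this assay, the change at the double-bonded chain carbon bound to a carbonyl carbon and a double-bonded chain carbon now stands alone: (4-bromophenyl)sulfonyl in place of (4-methylphenyl)sulfanyl gives a 10-fold higher number from compound 2 to compound 3 (1.00 log units; beyond the scatter), so this place affects inhibition of growth and this swap weakens it. With (4-bromophenyl)sulfonyl held constant, the aryl group on the double-bonded chain carbon bound to a double-bonded chain carbon also matters: 3-hydroxy-4-methoxyphenyl in place of 2,4-dichlorophenyl gives a 5.0-fold lower number from compound 1 to compound 3 (0.70 log units; beyond the scatter), so the wide gap between compound 1 and compound 2 is spread over two places, each with a step beyond the scatter. No supporting measurement bears on the reason for either step.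

The step to compound 3 alters the sulfur oxidation level and the para-free naming of the ring group together, as sulfanyl becomes sulfonyl and methyl gives way to bromo, so the compounds shown cannot assign the loss to either part. As far as these compounds go, whether (4-methylphenyl)sulfonyl or (4-bromophenyl)sulfanyl at this place would sit nearer compound 2 or compound 3 stays open, as does the effect of an amine on the aryl ring.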